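Series notes: an aromatic tail exchanged for a plain chain

The source may hold more compounds than are shown below. What is called first, only, known or untested is meant among the compounds shown, and "the series" means these compounds.

Measured so far in a functional assay on cells (T-cell line, Homo sapiens) for inhibition; a lower number here means a stronger inhibitor, a higher number a weaker inhibitor:
compound 1, `COc1ccc(CCCN2CCC(COC(c3ccc(Cl)cc3)c3ccc(Cl)cc3)CC2)cc1`, 1100 nM
compound 2, `COc1ccc(CCCN2CCC(=CCC(c3ccccc3)c3ccccc3)CC2)cc1`, 400 nM
compound 3, `Clc1ccc(CCCN2CCC(COC(c3ccccc3)c3ccccc3)CC2)cc1`, 500 nM

Compound 3 holds the second highest of the three numbers. Its nearest neighbour is compound 2, whose number sits lower but within the scatter, so the two cannot be ranked against each other. Compound 1 gives a higher number, and that gap lies beyond the scatter; compound 3 is therefore the stronger inhibitor of those two in this assay.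

The next compound carries compound 3 onward. Compound 4, `CCCCCCCCN1CCC(COC(c2ccccc2)c2ccccc2)CC1`, differs from it in one place: pentyl in place of 4-chlorophenyl on a saturated chain carbon, three bonds along the chain from an amine nitrogen in a ring. For the measured compounds named here, no measured pair in the set shows this kind of exchange, so the expectation rests only on the value of compound 3 and on the fact that the chain replaces an aromatic ring. A moderate weakening is expected, beyond the scatter but not large: the step from compound 3 to compound 4 is estimated as a 3.0-fold higher number from compound 3 to compound 4 (0.48 log units; beyond the scatter). Compound 4 is therefore expected to give about 1500 nM in this assay, with a range from 400 nM to 6000 nM.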

Compound 4, half-maximal inhibitory concentration: 700 nM
Compound 4: middle estimate off by 2.1-fold (0.33 log units), on the high side; measured number inside the range.
By their numbers in this assay, from the lowest: compounds 2, 3, 4 and 1 (each within the scatter of the next, the first and the last beyond it).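

In this assay, the first exchange read at this position, on a saturated chain carbon, three bonds along the chain from an amine nitrogen in a ring, gives a 1.4-fold higher number from compound 3 to compound 4 (0.15 log units; within the scatter), so the two compounds cannot be ranked against each other. For this one pair, the 4-chlorophenyl group, with its six-membered aromatic ring and its chlorine, can give way to a pentyl group with no ring and no measurable loss of inhibition in this assay, so an aromatic ring at this place is not needed for a number in this range. This is a single exchange on a single core, and no supporting measurement is available to explain why the two numbers lie so close.

From the compounds shown here alone, it remains open whether this tolerance extends to a chain much shorter or longer than pentyl, such as ethyl or decyl, or to a chain that ends in a hydroxyl group or a carboxylic acid. Going by these compounds, it also remains open whether a pentyl group would be accepted in the same way on the cores of compound 1 and compound 2.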